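This account rests on a few compounds, and the source may have more. Where it says the series, first, only, none or still open, it means among the compounds named here.

Compound 1 `O=C1O[C@H]([C@@H](O)Cn2cc(-c3cc(C(F)(F)F)cc(C(F)(F)F)c3)nn2)C(OCc2ccccc2)=C1OCc1ccccc1` gives 33800 nM in a functional assay on HepG2 cells (Homo sapiens) for antiproliferative activity, read by MTT assay, with a stated time of 72 h; on this read-out higher numbers stand for weaker inhibition and lower numbers for stronger inhibition.
Compound 2 `COc1ccc(-c2cn(C/C=C3\OC(=O)C(OCc4ccccc4)=C3OCc3ccccc3)nn2)cc1` gives only a limit of the assay, > 100000 nM.
Compound 3 `CCCCCCCCCCc1cn(C[C@H](O)[C@H]2OC(=O)C(OCc3ccccc3)=C2OCc2ccccc2)nn1` gives 12200 nM.

Compound 3 stands at the lowest of the two numbers shown; the nearest number, that of compound 1, lies higher by a gap that exceeds the usual scatter, and compound 2 contributes only a limit (the limit of > 100000 nM in this assay, at which 1 of the 3 values shown sits). Going by the values given here, the three compounds share a core and differ in what hangs from the triazole, so no single-point step between measured compounds is available.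

Compound 4 `Cc1ccc(S(=O)(=O)NCc2cn(C[C@H](O)[C@H]3OC(=O)C(OCc4ccccc4)=C3OCc3ccccc3)nn2)cc1` differs from compound 3 by ((4-methylphenyl)sulfonyl)amino in place of nonyl on a saturated chain carbon bound to an aromatic carbon. The long hydrocarbon chain of compound 3, the compound with the lowest number, is thereby cut short and capped with a group that carries a donor and acceptors. Among the measured compounds, the aryl-bearing ones, compound 1 and compound 2, give higher numbers or a limit, while the chain-bearing compound 3 gives the lowest. On that basis compound 4 is expected to move toward weaker inhibition, with an estimated step of a 2.9-fold higher number from compound 3 to compound 4 (0.46 log units; beyond the scatter) that goes beyond the scatter. For compound 4 the estimate is 35000 nM, expected to lie between 10000 nM and 100000 nM.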

Compound 4, half-maximal inhibitory concentration: 24900 nM
Estimate against measurement, compound 4: 1.4-fold (0.15 log units) above; low and high end bracket the measured number.
By their numbers in this assay, from the lowest: compound 3; then compounds 4 and 1 (each within the scatter of the next). At a limit, above all of these: compound 2.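

In this assay, going by these compounds alone, the step of a 2.0-fold higher number from compound 3 to compound 4 (0.31 log units; beyond the scatter) is the first reading of a single change at this place, on a saturated chain carbon bound to an aromatic carbon, and it is modest but beyond the scatter. With the rest of the molecule held constant, it shows that nonyl can give way to ((4-methylphenyl)sulfonyl)amino, which brings an aromatic ring, a hydrogen-bond donor and hydrogen-bond acceptors, and that inhibition shifts only modestly, with compound 4 at 24900 nM. Nothing measured among these compounds accounts for the size of this step.

Because the chain is removed and the aryl sulfonyl amino group is added in one change, the compounds shown do not separate the effect of losing nonyl from that of gaining ((4-methylphenyl)sulfonyl)amino. Going by these compounds, a butyl chain, a simple amine or a carboxylic acid at this same place would help to tell these apart, and whether a longer chain than decyl would lower the number further also remains open.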